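The source may hold more compounds than are shown below. What is called first, only, known or untested is meant among the compounds shown, and "the series" means these compounds.

In a functional assay on CAL-51 cells (Homo sapiens) for antiproliferative activity, read by luminescence and CellTiter-Glo, with a stated time of 3 days (on this read-out lower numbers stand for stronger inhibition and higher numbers for weaker inhibition), two compounds with the same core have been measured so far, and they differ only in the group on an oxygen on an aromatic ring. Compound 1 `COc1cc(C(=O)N(C)C)ccc1Nc1nc(OC2CCCC2)c2cc[nH]c2n1`, which carries cyclopentyl, gives 497 nM. Compound 2 `COc1cc(C(=O)N(C)C)ccc1Nc1nc(OC2CCOCC2)c2cc[nH]c2n1`, which carries oxan-4-yl, gives 198 nM, the lower of the two numbers and so the stronger inhibition of this pair.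

The next structure is compound 3 `COc1cc(C(=O)N(C)C)ccc1Nc1nc(OC(C)C)c2cc[nH]c2n1`, with isopropyl in place of oxan-4-yl on that oxygen: isopropyl in place of oxan-4-yl on an oxygen on an aromatic ring. Going by the values given here, only one measured step bears on this change: a 2.5-fold lower number from compound 1 to compound 2 (0.40 log units; beyond the scatter). This modest step shows that the number can shift when the group on this oxygen is exchanged. Like cyclopentyl, isopropyl is made of carbon alone, so the new change partly runs that step backwards. However, no measured compound tests a group without a ring. A step in this assay towards a higher number, of similar or smaller size, is therefore expected. The expected change is a 1.9-fold higher number from compound 2 to compound 3 (0.28 log units; within the scatter). For compound 3 the estimated value is 380 nM, with a range of 160 nM to 900 nM.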

Compound 3, half-maximal inhibitory concentration: 1270 nM
The estimate for compound 3 lay 3.3-fold (0.52 log units) below the measured number; the whole stated range lies below it.
By their numbers in this assay, from the lowest: compound 2; then compound 1; then compound 3.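

In this assay, going by these compounds alone, there is a step of a 6.4-fold higher number from compound 2 to compound 3 (0.81 log units; beyond the scatter) that is beyond the usual scatter and shows that losing the oxan-4-yl group costs more here than the one earlier step could reveal. The further step a 2.6-fold higher number from compound 1 to compound 3 (0.41 log units; beyond the scatter) is also beyond the scatter and places isopropyl behind cyclopentyl as well, so compound 3 is the weakest of the three, and the two groups made only of carbon do not give matching numbers; among these three compounds, both groups with a ring give lower numbers than the open isopropyl group, and none goes against this. Nothing measured here explains why the number moves in this way.

Going from oxan-4-yl to isopropyl removes the ring, the ring oxygen and part of the group's size all at once, so these compounds cannot show which of these differences counts. A small ring such as cyclopropyl, a longer chain such as n-butyl, or piperidin-4-yl, which has an amine nitrogen in place of the ring oxygen, on the same oxygen would remain to be compared.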